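Amide substituent variation on the shared core

The source may hold more compounds than are shown below. What is called first, only, known or untested is meant among the compounds shown, and "the series" means these compounds.

Measured so far:
compound 1, `CCn1c(C(=O)NCCN)ccc1C(CC)(CC)c1ccc(OCS(=O)(=O)c2ccccc2)c(C)c1`: 6890 nM
compound 2, `CCn1c(C(=O)N[C@H](CO)CCO)ccc1C(CC)(CC)c1ccc(OCS(=O)(=O)c2ccccc2)c(C)c1`: 12100 nM

Compound 1 gives the lowest of the two numbers in a functional assay on PC-3 cells (Homo sapiens) for antiproliferative activity, read by MTT assay, with a stated time of 24 h; a higher number here means a weaker inhibitor, a lower number a stronger inhibitor; its nearest neighbour is compound 2, at a 1.8-fold higher number from compound 1 to compound 2 (0.24 log units; within the scatter), so the two are not separable.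

Compound 3, `CCn1c(C(=O)N[C@H](CC(=O)O)C(=O)O)ccc1C(CC)(CC)c1ccc(OCS(=O)(=O)c2ccccc2)c(C)c1`, is not yet measured. It differs from compound 1 by 1,2-dicarboxyethyl in place of 2-aminoethyl on an amide-type nitrogen.

Going by the values given here, the only step that bears on this position is the one from compound 1 to compound 2, where a different group on the same amide-type nitrogen gave a 1.8-fold higher number from compound 1 to compound 2 (0.24 log units; within the scatter). Among the compounds with values here, with one step in hand, and that one within the scatter, a small step is expected here too, if anything towards a higher number, as the one measured change at this position went that way.

For compound 3 the estimate is 11000 nM, range 4500 nM to 30000 nM, corresponding to a 1.6-fold higher number from compound 1 to compound 3 (0.20 log units; within the scatter).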

Compound 3, half-maximal inhibitory concentration: > 50000 nM
Compound 3: a limit, no number (the forecaster's own chance of this, stated with the estimate: 10%); at least 4.5-fold (0.65 log units) between middle value and limit.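

In this assay, compound 1 and compound 2 could not be separated, but the amide-type nitrogen now proves sensitive to its substituent: 1,2-dicarboxyethyl gives an at least 7.2-fold higher number from compound 1 to compound 3 (0.86 log units; beyond the scatter), and in place of 3-hydroxy-1-(hydroxymethyl)propyl it gives an at least 4.1-fold higher number from compound 2 to compound 3 (0.61 log units; beyond the scatter). For compound 3 the result is a limit of the assay, not a number: the limit of > 50000 nM in this assay, at which 1 of the 3 values shown sits. Going by these compounds alone, both steps therefore set only a lower bound on the size of the change, yet they are the first at this position to lie beyond the scatter.

On these data alone, it remains open whether a single carboxylic acid on a shorter chain would give a step of similar size or whether both carboxylic acids are needed. Also open, as far as these compounds go, is whether a longer chain ending in an amine would separate from compound 1.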